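Dropping Two Methoxy Groups From a Sulfonamide Diamine

The source may report more compounds than this note shows. Statements on the series, on what has been measured and on what is new or still open speak of the compounds shown alone.

Measured compounds:
- compound 1 `O=S(=O)(NCCNCc1cccc2ccccc12)c1cc(C(F)(F)F)cc(C(F)(F)F)c1`: 19000 nM
- compound 2 `O=S(=O)(NCCNCc1ccc(-c2ccccc2)cc1)c1cc(C(F)(F)F)cc(C(F)(F)F)c1`: 2700 nM
- compound 3 `COc1ccc(CNCCCNS(=O)(=O)c2cc(C(F)(F)F)cc(C(F)(F)F)c2)cc1OC`: 3600 nM

In a functional assay on BE(2)-C cells (Homo sapiens) for inhibition, read by MTT assay, with a stated time of 72 h (on this read-out lower numbers stand for stronger inhibition of growth and higher numbers for weaker inhibition of growth), compound 3 sits second highest of the three numbers. Its nearest neighbour is compound 2, whose value lies within the scatter of compound 3, so the two cannot be ranked; compound 1 lies furthest away, beyond the scatter, with the weaker number.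

Compound 4 `O=S(=O)(NCCCNCc1ccccc1)c1cc(C(F)(F)F)cc(C(F)(F)F)c1` differs from compound 3 in one place: phenyl in place of 3,4-dimethoxyphenyl on a saturated chain carbon bound to an amine nitrogen. Among the measured compounds shown here, no measured pair shows this change, so its effect is unknown from the data. Removing two acceptors from the outer ring is expected to give, if anything, a modest step toward weaker inhibition in this assay, possibly none beyond the scatter. For compound 4 the expected value is 6000 nM, with a range from 2000 nM to 18000 nM, which is an estimated step of a 1.7-fold higher number from compound 3 to compound 4 (0.22 log units; within the scatter).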

Compound 4, concentration for 50% growth inhibition: 12000 nM
Compound 4: the middle estimate sits 2.0-fold (0.30 log units) below what was measured; low and high end bracket the measured number.
By their numbers in this assay, from the lowest: compounds 2 and 3 (each within the scatter of the next); then compounds 4 and 1 (each within the scatter of the next).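

Swapping 3,4-dimethoxyphenyl for phenyl gives a 3.3-fold higher number from compound 3 to compound 4 (0.52 log units; beyond the scatter) in this assay, so this position is sensitive to the change. The outer ring here is not a passive part of the molecule: with the two methoxy groups gone, inhibition of growth is weaker. No measurement shown explains why the step occurs.

On these data alone, it remains open whether a single methoxy group would be enough to keep the stronger inhibition. It is also unclear how a different group on the ring, such as a hydroxyl or a chlorine, would compare.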